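Amide aryl variation on the shared core: paw edema series

The source may hold more compounds than are shown below. What is called first, only, known or untested is meant among the compounds shown, and "the series" means these compounds.

Measured so far:
compound 1 `COc1cc2c(cc1OC)C(CC(=O)Nc1cccc(C)c1)CC2` — 38%
compound 2 `COc1ccccc1NC(=O)CC1CCc2cc(OC)c(OC)cc21` — 24.1%

In a functional assay on the whole organism (strain Wistar) for inhibition, with Rattus norvegicus as the target, read by paw edema, with a stated time of 6 h, at a dose of 100 mg/kg (a lower number here means less inhibition, a higher number more inhibition at the dose given (going by the name of the read-out)), compound 1 gives 38%, and compound 2 gives 24.1%. Within the data shown here, the one step measured so far, a number 13.9 percentage points lower from compound 1 to compound 2 (beyond the scatter), is the only piece of evidence on the amide-type nitrogen substituent, and it shows that the aryl group on that nitrogen does move the read-out beyond the scatter. Among the measured compounds shown here, compound 2 thus stands lowest of the two numbers known, with compound 1 the nearest and higher.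

Compound 3 `COc1cc2c(cc1OC)C(CC(=O)Nc1ccccn1)CC2` carries a new group on the same nitrogen: pyridin-2-yl in place of 2-methoxyphenyl on an amide-type nitrogen. For the measured compounds named here, no measured step covers this particular exchange; the step from compound 1 to compound 2 concerns a different pair of groups and only tells that changes here can be of modest size. Going by the values given here, with no direct precedent, compound 3 is expected to land near the middle of the range already seen, and the estimated step of a number 5.9 percentage points higher from compound 2 to compound 3 (within the scatter) is taken as a small rise that need not exceed the scatter. Compound 3 is thus estimated at 30%, within 15% to 45%.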

Compound 3, a percentage reported as inhibition, in the whole organism at one dose (the size of the read-out at that dose, not a potency): 29.6%
Beside the measured number, compound 3's estimate is 0.4 percentage points above it, within the range that was stated.
By their numbers in this assay, from the lowest: compounds 2, 3 and 1 (each within the scatter of the next, the first and the last beyond it).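

In this assay, pyridin-2-yl in place of 2-methoxyphenyl on the amide-type nitrogen gives a number 5.5 percentage points higher from compound 2 to compound 3 (within the scatter), and pyridin-2-yl in place of 3-methylphenyl gives a number 8.4 percentage points lower from compound 1 to compound 3 (within the scatter). The group on this nitrogen therefore need not be an aromatic ring of carbon only: a six-membered aromatic ring with 1 hetero atom, carrying no further substituent, gives a number within the scatter of both earlier compounds, although those two lie beyond the scatter of each other. The three compounds alone cannot separate compound 3 from either neighbour, and no supporting data bear on why the numbers fall as they do.

Still open, from the compounds shown here alone, is whether this nitrogen accepts something other than a six-membered aromatic ring, such as a benzyl group or a longer alkyl chain, and whether a carboxylic acid or an amine on the aryl group moves the number beyond the scatter. All three compounds carry the shared core unchanged and are read at a single dose, so the compounds shown say nothing about changes to that core or about potency.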